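The source may hold more compounds than are shown below. What is called first, only, known or untested is meant among the compounds shown, and "the series" means these compounds.

Of the compounds shown here, three built on one shared core have been measured in a functional assay on HCT-116 cells (Homo sapiens) for antiproliferative activity, read by MTT assay, with a stated time of 48 h; on this read-out higher numbers stand for weaker inhibition and lower numbers for stronger inhibition. Compound 1 `COc1cc(N(Cc2ccc(C)cc2)C(=O)CSc2nc3ccccc3s2)cc(OC)c1OC` gives only a limit, > 80000 nM. Compound 2 `COc1ccc(CN(C(=O)CSc2nc3ccccc3s2)c2cc(OC)c(OC)c(OC)c2)cc1N` gives 491 nM, and compound 3 `COc1ccc(CN(C(=O)CSc2nc3ccccc3s2)c2cc(OC)c(OC)c(OC)c2)cc1N=[N+]=[N-]` gives 2860 nM, the higher of the two numbers. The step of a 5.8-fold higher number from compound 2 to compound 3 (0.77 log units; beyond the scatter) is modest. Compound 4 `COc1cc(N(Cc2ccc(Cl)cc2)C(=O)CSc2nc3ccccc3s2)cc(OC)c1OC` differs from compound 3 by 4-chlorophenyl in place of 3-azido-4-methoxyphenyl on a saturated chain carbon bound to an amide-type nitrogen. Among the compounds with values here, the steps that bear on this change are an at least 160-fold lower number from compound 1 to compound 2 (2.21 log units; beyond the scatter) and an at least 27-fold lower number from compound 1 to compound 3 (1.44 log units; beyond the scatter), both large, and both run from a ring lacking the amino or azido group to one carrying it. Compound 4 goes back to such a ring, so a large upward step, a 14-fold higher number from compound 3 to compound 4 (1.15 log units; beyond the scatter), is expected in this assay, possibly reaching the limit (the limit of > 80000 nM in this assay, at which 1 of the 3 values shown sits). Compound 4 is thus estimated at 40000 nM, within 6000 nM to 100000 nM.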

Compound 4, half-maximal inhibitory concentration: 603000 nM
Compound 4: middle estimate off by 15-fold (1.18 log units), on the low side; measured number above the stated range.
By their numbers in this assay, from the lowest: compound 2; then compound 3; then compound 4.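

With 4-chlorophenyl on the saturated chain carbon bound to an amide-type nitrogen, the number climbs far past those of the amino and azido rings, with a 210-fold higher number from compound 3 to compound 4 (2.32 log units; beyond the scatter) and a 1200-fold higher number from compound 2 to compound 4 (3.09 log units; beyond the scatter). This ring gives a real number rather than a limit, so the reach of this position now has a measured span. The step from compound 1 to compound 4 cannot be read: the limit of > 80000 nM in this assay, at which 1 of the 4 values shown sits.

On these data alone, what stays open is whether the 4-methoxy group or the amino or azido group accounts for the lower numbers of compound 2 and compound 3. As far as these compounds go, a hydroxyl or a carboxylic acid in place of the amino group also remains untested here.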